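The compounds below may be only part of what the source reports. "The series", "measured", "known", "first", "only" and "open" are said of these compounds alone.

The measured compounds:
Compound 1, `N#Cc1ccc(Nc2nccc(OCC(=O)Nc3cccc(Cl)c3)n2)cc1`, gives > 329000 nM, which is a limit of the assay rather than a number.
Compound 2, `N#Cc1ccc(Nc2nccc(OCC(=O)Nc3ccc([N+](=O)[O-])cc3)n2)cc1`, gives > 320000 nM, again a limit of the assay.
Compound 3, `Cc1cc(OCC(=O)Nc2cccc(Cl)c2)nc(Nc2ccc(C#N)cc2)n1`, gives 32200 nM.

All three were tested in an ADME assay on MT4 cells (Homo sapiens) for cytotoxicity, read by MTT assay, with a stated time of 5 days; a higher number here means that more compound is tolerated, a lower number that less compound is tolerated. Compound 1 sits at the limit of > 329000 nM in this assay, at which 1 of the 3 values shown sits. Compound 2 sits at the limit of > 320000 nM in this assay, at which 1 of the 3 values shown sits. The change from compound 1 to compound 2 is 4-nitrophenyl in place of 3-chlorophenyl on an amide-type nitrogen, and in this assay the step is a step that the two limits leave unreadable from compound 1 to compound 2. Compound 3 differs from compound 1 by methyl in place of hydrogen on an aromatic carbon, and in this assay that step is an at least 10-fold lower number from compound 1 to compound 3 (1.00 log units; beyond the scatter), so compound 3 is the only one of the three that gives a number rather than a limit.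

Compound 4, `Cc1cc(OCC(=O)Nc2ccc([N+](=O)[O-])cc2)nc(Nc2ccc(C#N)cc2)n1`, has not yet been measured. It differs from compound 3 by 4-nitrophenyl in place of 3-chlorophenyl on an amide-type nitrogen. This is the same change as that from compound 1 to compound 2, made on the core of compound 3 rather than on the core of compound 1; the two cores differ by the methyl just described. Because the earlier step in this assay is a step that the two limits leave unreadable from compound 1 to compound 2, its size gives no guide, and the expectation for compound 4 can rest only on compound 3 with its value 32200 nM. The step from compound 3 to compound 4 in this assay is therefore expected to be a 1.2-fold higher number from compound 3 to compound 4 (0.09 log units; within the scatter), with wide uncertainty. Compound 4 is expected to give about 40000 nM, between 10000 nM and 200000 nM.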

Compound 4, half-maximal cytotoxic concentration: > 309000 nM
Compound 4: a limit, no number; the forecaster's own chance of this, stated with the estimate: 20%; at least 7.7-fold (0.88 log units) between middle value and limit.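

In this assay, 4-nitrophenyl in place of 3-chlorophenyl on an amide-type nitrogen, made on the core of compound 3, gives an at least 9.5-fold higher number from compound 3 to compound 4 (0.98 log units; beyond the scatter). Compound 4 therefore stands at a limit of the assay rather than at a number: the limit of > 309000 nM in this assay, at which 1 of the 4 values shown sits. This shows that the change is readable on the core of compound 3 but does not show that it carries over from the core of compound 1, since compound 1 and compound 2 both give limits, and the steps from compound 1 to compound 2 and from compound 2 to compound 4 cannot be read, so the size of the change on the two cores cannot be compared and an at least 10-fold lower number from compound 1 to compound 3 (1.00 log units; beyond the scatter) has no readable counterpart among the 4-nitrophenyl compounds.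

The compounds shown carry only two groups on the amide-type nitrogen and only hydrogen or methyl on the aromatic carbon, so they say nothing about how a phenyl bearing an amine or a carboxylic acid would behave on either core. From the compounds shown here alone, whether a longer chain in place of the methyl would give a number or a limit also remains open.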